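Compound 3 and a swap to 3,5-dimethoxyphenyl

The source may report more compounds than this note shows. Statements on the series, on what has been measured and on what is new or still open speak of the compounds shown alone.

Compound 1 `COc1cc(OC)cc(N2CCN(C(=O)c3oc(C)nc3-c3ccc(F)cc3)CC2)c1` gives 12.9%
Compound 2 `Cc1cc(C)cc(N2CCN(C(=O)c3oc(C)nc3-c3ccccc3)CC2)c1` gives 25.6%
Compound 3 `Cc1nc(-c2ccccc2)c(C(=O)N2CCN(c3cc(Cl)cc(Cl)c3)CC2)o1` gives 66.3%

In an ADME assay (liver) for metabolic stability, with Liver microsome (Homo sapiens) as the target, read by LC-MS, using microsomes, with a stated time of 1 h, tested at 5 uM (a lower number here means that less of the compound is left, a higher number that more of the compound is left), compound 3 stands highest of the three (66.3%), with compound 2 the nearest and compound 1 the furthest away. Compound 4 `COc1cc(OC)cc(N2CCN(C(=O)c3oc(C)nc3-c3ccccc3)CC2)c1` has not yet been measured. It keeps the rest of compound 3 and changes one group: 3,5-dimethoxyphenyl in place of 3,5-dichlorophenyl on an amine nitrogen in a ring. In short, 3,5-dimethoxyphenyl comes in place of 3,5-dichlorophenyl on an amine nitrogen in a ring.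

Going by the values given here, the one measured step at this place is a number 40.7 percentage points higher from compound 2 to compound 3 (beyond the scatter), a large change, with 3,5-dichlorophenyl in place of 3,5-dimethylphenyl. So the high number of compound 3 goes with its 3,5-dichlorophenyl group, on the evidence of this single pair. Compound 1 (12.9%) already carries 3,5-dimethoxyphenyl, but it differs from compound 4 elsewhere in the molecule, so it is a guide and not a direct comparison. Leaving 3,5-dichlorophenyl is therefore expected to cost a large amount in this assay, well beyond the scatter. The expected change is a number 48.3 percentage points lower from compound 3 to compound 4 (beyond the scatter) as an estimate. The estimated value for compound 4 is 18%, with an expected range from 7% to 35%.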

Compound 4, percent of the compound remaining: 15.8%
Compound 4: the middle estimate sits 2.2 percentage points above what was measured; measured number inside the range.
By their numbers in this assay, from the lowest: compounds 1, 4 and 2 (each within the scatter of the next, the first and the last beyond it); then compound 3.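

In this assay, putting 3,5-dimethoxyphenyl on the amine nitrogen in place of 3,5-dichlorophenyl gives a number 50.5 percentage points lower from compound 3 to compound 4 (beyond the scatter), so a second replacement group loses the high number as well, and that loss is not tied to 3,5-dimethylphenyl alone. The two replacements cannot be told apart, with a number 9.8 percentage points lower from compound 2 to compound 4 (within the scatter), so among these three groups only 3,5-dichlorophenyl stands apart at this position. Hydrogen in place of fluoro on an aromatic carbon gives a number 2.9 percentage points higher from compound 1 to compound 4 (within the scatter), so with 3,5-dimethoxyphenyl in place, that swap makes no difference that can be read here.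

Nothing shown here gives a reason why 3,5-dichlorophenyl stands apart from the other two groups. Going by these compounds, it also remains open whether the high number needs both chlorines, and whether a phenyl ring with a single chlorine, 3,5-difluorophenyl or 3,5-bis(trifluoromethyl)phenyl on the same nitrogen would keep it, or whether fluoro on the aromatic carbon would matter alongside 3,5-dichlorophenyl.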